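Lactone and ether series: methoxy addition on the phenyl ring

The source may report more compounds than this note shows. Statements on the series, on what has been measured and on what is new or still open speak of the compounds shown alone.

Measured so far in a functional assay on HL-60 cells (Homo sapiens) for cytotoxicity, read by WST assay, with a stated time of 48 h; a higher number here means that more compound is needed for the effect, a lower number that less compound is needed:
compound 1, `O=C1OC[C@H](Cc2ccccc2)[C@H]1Cc1ccccc1`, gives 77000 nM
compound 2, `COc1cccc(C[C@H]2C(=O)OC[C@@H]2Cc2ccccc2)c1`, gives 66000 nM
compound 3, `Oc1ccc(C[C@H]2COC[C@@H]2Cc2ccc(Cl)c(Cl)c2)cc1`, gives 31000 nM

Compound 1 and compound 2 share a core; the difference between them is methoxy in place of hydrogen on an aromatic carbon. This gave a 1.2-fold lower number from compound 1 to compound 2 (0.07 log units; within the scatter), so the two numbers cannot be ordered. Compound 3 is built on a different core, and the difference between the two cores is not broken down here. In this assay compound 3 stands lowest of the three numbers, and its steps to compound 1 and to compound 2 are both beyond the scatter.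

Compound 4, `COc1cc(C[C@H]2COC[C@@H]2Cc2ccc(Cl)c(Cl)c2)ccc1O`, is not yet measured. It differs from compound 3 by methoxy in place of hydrogen on an aromatic carbon. Within the data shown here, this is the same kind of change as that from compound 1 to compound 2, not the same: in compound 4 the entering group sits ortho to a hydroxy group, which has no counterpart on the ring of compound 2, and the cores differ as well. Among the measured compounds shown here, the only measured precedent is a 1.2-fold lower number from compound 1 to compound 2 (0.07 log units; within the scatter). Resting on that alone, the step is expected to be a 1.2-fold lower number from compound 3 to compound 4 (0.08 log units; within the scatter), a small move in this assay, because the precedent is a 1.2-fold lower number from compound 1 to compound 2 (0.07 log units; within the scatter). For compound 4 the expected value is 26000 nM, with a range estimated from 12000 nM to 55000 nM.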

Compound 4, half-maximal effective concentration: 21000 nM
Beside the measured number, compound 4's estimate is 1.2-fold (0.09 log units) above it; the range from low to high includes it.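

In this assay, methoxy in place of hydrogen on an aromatic carbon gives a 1.5-fold lower number from compound 3 to compound 4 (0.17 log units; within the scatter), so the two numbers cannot be ordered. Set beside the earlier step, the change reads alike on the two cores, with neither step leaving the scatter and no difference to read between them: the same change on two cores in this assay, a 1.2-fold lower number (0.07 log units; within the scatter) from compound 1 to compound 2 and a 1.5-fold lower number (0.17 log units; within the scatter) from compound 3 to compound 4, 1.3-fold (0.10 log units) apart, within the scatter of two such steps. Among these compounds, this shows only that two small steps agree on two cores, with the entering methoxy ortho to a hydroxy group in compound 4 and no such group in compound 2; it does not show that the change would stay small on other cores or at other places on the ring, and it does not separate any part played by the hydroxy group.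

The compounds shown leave open whether a group other than methoxy at the same place, such as ethoxy, fluorine or an amine, would move the number beyond the scatter. They also leave open what a carboxylic acid in place of the hydroxy group would do on the core of compound 3.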